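The source may report more compounds than this note shows. Statements on the series, on what has been measured and on what is new or still open speak of the compounds shown alone.

Working notes on the series. In a functional assay on DU-145 cells (Homo sapiens) for cytotoxicity, read by sulforhodamine B assay, with a stated time of 48 h (a lower number here means a stronger inhibitor, a higher number a weaker inhibitor), compound 1 `COc1cc(C2=NO[C@]3(C2)C(=O)O[C@@H]2[C@H]3CC[C@H](C)[C@]3(O)C=CC(=O)[C@@]23C)ccc1O` gives 71000 nM, compound 2 `Cc1ccccc1C1=NO[C@]2(C1)C(=O)O[C@@H]1[C@H]2CC[C@H](C)[C@]2(O)C=CC(=O)[C@@]12C` gives 12000 nM and compound 3 `Cc1cccc(C2=NO[C@]3(C2)C(=O)O[C@@H]2[C@H]3CC[C@H](C)[C@]3(O)C=CC(=O)[C@@]23C)c1` gives 28000 nM, the second highest of the three numbers. Compound 4 `Cc1ccc(C2=NO[C@]3(C2)C(=O)O[C@@H]2[C@H]3CC[C@H](C)[C@]3(O)C=CC(=O)[C@@]23C)cc1` has not yet been measured. It differs from compound 3 as follows: 4-methylphenyl in place of 3-methylphenyl on a carbon with a double bond to nitrogen. The closest measured change is 3-methylphenyl in place of 2-methylphenyl, a 2.3-fold higher number from compound 2 to compound 3 (0.37 log units; beyond the scatter), a modest step. The two steps away from the 4-hydroxy-3-methoxyphenyl group, a 5.9-fold lower number from compound 1 to compound 2 (0.77 log units; beyond the scatter) and a 2.5-fold lower number from compound 1 to compound 3 (0.40 log units; beyond the scatter), are also modest, but they exchange a different substituent. Among the compounds with values here, no measurement yet shows what the 4-methylphenyl group does, so the direction remains open, and no step beyond the scatter is expected in this assay. The expected step is a 1.1-fold lower number from compound 3 to compound 4 (0.05 log units; within the scatter). For compound 4 the estimated value is 25000 nM, with an expected range of 11000 nM to 60000 nM.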

Compound 4, half-maximal inhibitory concentration: 14000 nM
Beside the measured number, compound 4's estimate is 1.8-fold (0.25 log units) above it, and the stated range covers the measured number.
By their numbers in this assay, from the lowest: compounds 2, 4 and 3 (each within the scatter of the next, the first and the last beyond it); then compound 1.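

With the third methylphenyl isomer in hand, this assay gives a 2.0-fold lower number from compound 3 to compound 4 (0.30 log units; within the scatter) and a 1.2-fold higher number from compound 2 to compound 4 (0.07 log units; within the scatter), so the 4-methylphenyl group at this carbon with a double bond to nitrogen cannot be told apart from either the 3-methylphenyl or the 2-methylphenyl group, though compounds 2 and 3 do differ beyond the scatter. With a 5.1-fold lower number from compound 1 to compound 4 (0.71 log units; beyond the scatter), beyond the scatter, all three methylphenyl compounds now stand at lower numbers than compound 1, with no exception among compounds 2, 3 and 4. No evidence is available that would explain these differences.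

Going by these compounds, it remains open how an amine or a carboxylic acid on the phenyl ring, or a longer chain such as ethyl in place of methyl, would read here. The hydroxy and methoxy groups of compound 1 also leave together in every step, so their separate contributions remain unresolved.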